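Thiophene amide in place of propoxymethyl amide on a shared core

The source may report more compounds than this note shows. Statements on the series, on what has been measured and on what is new or still open speak of the compounds shown alone.

Measured in an ADME assay on Vero cells (Chlorocebus sabaeus) for cytotoxicity, read by resazurin assay, with a stated time of 3 days; on this read-out higher numbers stand for weaker inhibition and lower numbers for stronger inhibition:
compound 1 `CCOCCOC(=O)Nc1cc2nc(C3CCCCC3)[nH]c2cc1N(C)C`, a limit only, > 100 ug/mL
compound 2 `CN(C)c1cc2[nH]c(C3CCCCC3)nc2cc1NC(=O)c1ccc(C(C)(C)C)cc1`, a limit only, > 100 ug/mL
compound 3 `CCCOCC(=O)Nc1cc2nc(C3CCCCC3)[nH]c2cc1N(C)C`, a limit only, < 50 ug/mL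

Compound 3 sits at the lower limit; the steps to it are an at least 2.0-fold lower number from compound 1 to compound 3 (0.30 log units; that floor lies within the scatter) and an at least 2.0-fold lower number from compound 2 to compound 3 (0.30 log units; that floor lies within the scatter). The step between the two upper values is a step that the two limits leave unreadable from compound 1 to compound 2. Compound 4 `CN(C)c1cc2[nH]c(C3CCCCC3)nc2cc1NC(=O)c1cccs1` differs from compound 3 by thiophen-2-yl in place of propoxymethyl on a carbonyl carbon. The step from compound 2 to compound 3 bears on this most, as it exchanged 4-(tert-butyl)phenyl for propoxymethyl, the reverse sense of the present change; its true size stays unreadable because its ends sit at the limit of > 100 ug/mL in this assay, at which 2 of the 3 values shown sit, and (the limit of < 50 ug/mL in this assay, at which 1 of the 3 values shown sits). An upward step is therefore expected, an at least 1.6-fold higher number from compound 3 to compound 4 (0.20 log units; that floor lies within the scatter). Compound 4 is estimated at 80 ug/mL, from 25 ug/mL to 200 ug/mL.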

Compound 4, half-maximal inhibitory concentration: > 100 ug/mL
Compound 4 gave a limit, no number; the forecaster's own chance of this, stated with the estimate: 55%; at least 1.2-fold (0.09 log units) between middle value and limit.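

In this assay, thiophen-2-yl on the carbonyl carbon gives an at least 2.0-fold higher number from compound 3 to compound 4 (0.30 log units; that floor lies within the scatter), although the two groups count the same number of heavy atoms. Going by these compounds alone, compound 3 thus remains the only one of the four compounds at the lower limit, while the ring-bearing compounds 2 and 4 and the ring-free compound 1 all sit at the upper limit. The steps from compound 1 and from compound 2 to compound 4 cannot be read, as both ends of each are limits.

The compounds shown leave open whether a plain butyl chain or an amine on that carbonyl carbon would stay with compound 3 or with compound 4.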